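The compounds below may be only part of what the source reports. "The series", "measured", "known", "first", "only" and "open" are said of these compounds alone.

Within the data shown here, in an ADME assay for permeability, using PAMPA, at pH 7.4 (on this read-out lower numbers stand for lower permeability and higher numbers for higher permeability), compound 1 `Cc1cc(NC(=O)Nc2ccc(N(C)C)cc2)c2ccccc2n1` gives 2 10^-6 cm/s and compound 2 `Cc1cc(NC(=O)Nc2ccc(OC(F)(F)F)cc2)c2ccccc2n1` gives 531 10^-6 cm/s as the higher of the two numbers so far. Among the measured compounds shown here, the only measured step is a 270-fold higher number from compound 1 to compound 2 (2.42 log units; beyond the scatter) and it is large, lying beyond the scatter: trifluoromethoxy replaces dimethylamino on an aromatic carbon. Compound 3 `Cc1cc(NC(=O)Nc2ccc(Cl)cc2)c2ccccc2n1` is still to be measured in this assay and has chloro in place of trifluoromethoxy on an aromatic carbon. For the measured compounds named here, the measured step bears on this change only loosely: it starts from dimethylamino, which compound 3 does not carry, and no step between chloro and trifluoromethoxy has been measured. The expectation therefore stays near compound 2 at 531 10^-6 cm/s with a modest fall and nothing beyond the scatter. The estimated step is a 1.5-fold lower number from compound 2 to compound 3 (0.18 log units; within the scatter) and is small. Compound 3 is expected at 350 10^-6 cm/s with 120 10^-6 cm/s to 700 10^-6 cm/s as the estimated range.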

Compound 3, apparent permeability: 537 10^-6 cm/s
Estimate against measurement, compound 3: 1.5-fold (0.19 log units) below, and the stated range covers the measured number.
By their numbers in this assay, from the lowest: compound 1; then compounds 2 and 3 (each within the scatter of the next).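

In this assay, the step of a 1.0-fold higher number from compound 2 to compound 3 (0.00 log units; within the scatter) shows that, on this aromatic carbon para to a large group, chloro and trifluoromethoxy cannot be told apart, although chloro has fewer heavy atoms and no hydrogen-bond acceptor. The step of a 270-fold higher number from compound 1 to compound 3 (2.43 log units; beyond the scatter) is as large as the step of a 270-fold higher number from compound 1 to compound 2 (2.42 log units; beyond the scatter), so the wide gap from compound 1 now appears with two different replacements for dimethylamino rather than with trifluoromethoxy alone. Nothing available here accounts for this result.

As far as these compounds go, it remains open whether a primary amine, a methoxy group or a carboxylic acid at this place would give a number near that of compound 1 or near those of compound 2 and compound 3. The compounds shown also leave open whether chloro and trifluoromethoxy would match on a different core.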